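The compounds below may be only part of what the source reports. "The series", "measured", "known", "first", "only" and "open" are said of these compounds alone.

Compound 1 `CCCCc1ccc2[nH]c(-c3ccc(C(F)(F)F)cc3)c(/C=N\C)c2c1`: 32 nM
Compound 2 `CCCCc1ccc2[nH]c(-c3ccc(OC)cc3)c(/C=N\O)c2c1`: 40 nM

In a functional assay on MDA-MB-231 cells (Homo sapiens) for antiproliferative activity, with a stated time of 4 days (on this read-out higher numbers stand for weaker inhibition and lower numbers for stronger inhibition), compound 2 gives 40 nM and compound 1 gives 32 nM, two values that lie within the usual scatter of each other. Among the compounds with values here, no two measured compounds differ in one place alone, so no measured step bears directly on what follows.

Compound 3 `CCCCc1ccc2[nH]c(-c3ccc(C(F)(F)F)cc3)c(/C=N\O)c2c1` keeps the rest of compound 2 but carries trifluoromethyl in place of methoxy on an aromatic carbon. Compound 1 also bears trifluoromethyl and gives 32 nM, so no large shift is expected from this change in this assay. The expected step of a 1.1-fold lower number from compound 2 to compound 3 (0.06 log units; within the scatter) is estimated to stay within the scatter, with no firm direction. For compound 3 the estimated value is 35 nM, with an expected range from 14 nM to 90 nM.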

Compound 3, half-maximal inhibitory concentration: 497 nM
Compound 3: the middle estimate sits 14-fold (1.15 log units) below what was measured, outside the stated range (above it).
By their numbers in this assay, from the lowest: compounds 1 and 2 (each within the scatter of the next); then compound 3.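

In this assay, trifluoromethyl in place of methoxy on an aromatic carbon, para to a large group, brings a 12-fold higher number from compound 2 to compound 3 (1.09 log units; beyond the scatter) with hydroxy kept on the double-bonded nitrogen, so this position is not indifferent to the change. Hydroxy in place of methyl on the double-bonded nitrogen, with trifluoromethyl kept, brings a 16-fold higher number from compound 1 to compound 3 (1.19 log units; beyond the scatter), so trifluoromethyl does not by itself give the number that compound 1 shows at 32 nM and the outcome at the aromatic carbon depends on what the nitrogen carries. Nothing available here explains either step.

The compounds shown leave open how methoxy behaves with methyl on the double-bonded nitrogen. They also leave open whether a chlorine atom or an amine at the same aromatic carbon would follow methoxy or trifluoromethyl alongside hydroxy on the nitrogen.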